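Notes on the sulfonyl group in compound 1 and compound 4

This account rests on a few compounds, and the source may have more. Where it says the series, first, only, none or still open, it means among the compounds named here.

Measured in an ADME assay on S9 fraction from lung (Homo sapiens) for metabolic stability, read by LC-MS, using NADPH, with a stated time of 60 min, tested at 1 uM; a higher number here means that more of the compound is left, a lower number that less of the compound is left:
- compound 1 `CNC(=O)c1cc(S(=O)(=O)N2CCS[C@H]2C(=O)O[C@@H](Cc2c(Cl)c[n+]([O-])cc2Cl)c2ccc(OC(F)F)c(OCC3CC3)c2)cn1C` gives 63.5%
- compound 2 `CN(C)C(=O)c1cccc(S(=O)(=O)N2CSC[C@H]2C(=O)O[C@@H](Cc2c(Cl)c[n+]([O-])cc2Cl)c2ccc(OC(F)F)c(OCC3CC3)c2)c1` gives 52.1%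
- compound 3 `COc1ccc(S(=O)(=O)N2CCC[C@H]2C(=O)O[C@@H](Cc2c(Cl)c[n+]([O-])cc2Cl)c2ccc(OC(F)F)c(OCC3CC3)c2)cc1C(=O)N(C)C` gives 71.6%

Compound 1 stands within the scatter of compound 3 and beyond the scatter above compound 2, so it belongs with the better-retained part of this small set. Within the data shown here, the three measured compounds differ from one another in more than one place, and no measured pair isolates a single change.

Compound 4 `Cn1cnc(S(=O)(=O)N2CCS[C@H]2C(=O)O[C@@H](Cc2c(Cl)c[n+]([O-])cc2Cl)c2ccc(OC(F)F)c(OCC3CC3)c2)c1`, not yet measured in this assay, keeps the core of compound 1 and differs in one place: a group of 6 heavy atoms (4 carbon, 2 nitrogen; one five-membered aromatic ring with 2 hetero atoms) in place of a group of 10 heavy atoms (7 carbon, 2 nitrogen, 1 oxygen; one five-membered aromatic ring with 1 hetero atom), on a sulfonyl sulfur. In words, a smaller group, 1-methyl-1H-imidazol-4-yl, stands on the sulfonyl sulfur, whose other neighbour is the sulfonamide nitrogen in a ring.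

Among the measured compounds shown here, with no measured step to draw on, the expectation rests on compound 1 (63.5%), the only measured compound with the same core as compound 4. For the measured compounds named here, the range stays wide, since the data hold no direct precedent for this change. The expected size is small, an estimated a number 1.5 percentage points lower from compound 1 to compound 4 (within the scatter), with no direction expected beyond the scatter. Compound 4 is expected at 62% (estimated range 44% to 78%).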

Compound 4, percent of the compound remaining: 77.7%
Compound 4: the middle estimate sits 15.7 percentage points below what was measured, and the stated range covers the measured number.
By their numbers in this assay, from the lowest: compound 2; then compounds 1, 3 and 4 (each within the scatter of the next, the first and the last beyond it).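

In this assay, the change on the sulfonyl sulfur gives a number 14.2 percentage points higher from compound 1 to compound 4 (beyond the scatter), with 1-methyl-1H-imidazol-4-yl entering in place of the larger group. Among these compounds, this is the first comparison with the rest of the structure held constant, and it shows that the group at this position alone can shift the percent of compound remaining beyond the scatter, which the earlier compounds, differing in more than one place, could not show. No supporting measurement bears on the origin of this step, and the change alters the group's size, its aromatic ring and its hydrogen-bond donor count all at once.

The compounds shown leave open which of these differences carries the step, and whether a plain phenyl or a pyridinyl group on the sulfonyl sulfur would read closer to compound 1 or to compound 4. They also leave open whether 1-methyl-1H-imidazol-4-yl would give a similar step on the cores of compound 2 and compound 3, which carry other groups on the sulfonyl sulfur.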